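A few compounds are considered here, and "the series" means these few. Any claim that something is new, unique, unknown or untested is made for them only; others in the source may bear on it.

In an ADME assay on cells (T-cell, Mus musculus, strain BALB/c) for cytotoxicity, read by MTT assay, with a stated time of 48 h (a lower number here means that less compound is tolerated, a higher number that more compound is tolerated), compound 1 `COC(=O)c1cc(O)ccc1OC(=O)COc1cc(O)c2c(=O)cc(-c3ccccc3)oc2c1` gives 263000 nM and compound 2 `COC(=O)c1ccc(Cl)cc1OC(=O)COc1cc(O)c2c(=O)cc(-c3ccccc3)oc2c1` gives 265000 nM; the move a 1.0-fold higher number from compound 1 to compound 2 (0.00 log units; within the scatter) left the numbers alike, and compound 2 stands highest of the two, within the scatter of compound 1. Compound 3 `COC(=O)c1cccc(Cl)c1OC(=O)COc1cc(O)c2c(=O)cc(-c3ccccc3)oc2c1` differs from compound 2 by 2-chloro-6-(methoxycarbonyl)phenyl in place of 5-chloro-2-(methoxycarbonyl)phenyl on an oxygen next to a carbonyl group. Going by the values given here, only that one step bears on this change, and it showed no shift beyond the scatter, so compound 3 is expected to show a 1.0-fold lower number from compound 2 to compound 3 (0.01 log units; within the scatter), no step beyond the scatter. Compound 3 is therefore estimated at 260000 nM, between 130000 nM and 520000 nM.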

Compound 3, half-maximal cytotoxic concentration: 366000 nM
Beside the measured number, compound 3's estimate is 1.4-fold (0.15 log units) below it; measured number inside the range.
By their numbers in this assay, from the lowest: compounds 1, 2 and 3 (each within the scatter of the next).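

In this assay, 2-chloro-6-(methoxycarbonyl)phenyl in place of 5-chloro-2-(methoxycarbonyl)phenyl on an oxygen next to a carbonyl group gives (a 1.4-fold higher number from compound 2 to compound 3 (0.14 log units; within the scatter)), so rearranging the same atoms leaves the numbers alike. The group of compound 3 in place of the group of compound 1 likewise gives (a 1.4-fold higher number from compound 1 to compound 3 (0.14 log units; within the scatter)). Nothing shown explains these numbers. The compounds shown leave open what a carboxylic acid in place of the methoxycarbonyl group, or an amine in place of the chlorine, would give in this assay.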